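A few compounds are considered here, and "the series" means these few. Any claim that something is new, unique, unknown or untested is made for them only; others in the source may bear on it.

Compound 1 `CCCc1nc(-c2ccccc2)c(CNCCN2CCN(C(c3ccccc3)c3ccccc3)CC2)o1` and compound 2 `CCCc1nc(-c2ccccc2)c(CNCCN2CCN(c3ccccc3Cl)CC2)o1` share a core and differ only in the group carried on an amine nitrogen in a ring. In an assay on HEK293 cells for inhibition of Voltage-dependent T-type calcium channel subunit alpha-1G (Homo sapiens), read by fluorescence, tested at 10 uM (a higher number here means more inhibition at the concentration tested (going by the name of the read-out), a lower number less inhibition), compound 1 gives 71.9%, while compound 2 gives 60.1%. Compound 2 thus stands lowest of the two numbers, and the gap to compound 1 lies beyond the usual scatter; as the two groups differ in more than one feature, no single step can be read from that pair. Compound 3 `CCCc1nc(-c2ccccc2)c(CNCCN2CCN(c3ccc(C)cc3)CC2)o1` keeps everything in compound 2 except the change (4-methylphenyl in place of 2-chlorophenyl on an amine nitrogen in a ring). Nothing measured here shows what exchanging one aromatic group for another does to inhibition, so the step from compound 2 to compound 3 is expected to be small, a number 2.1 percentage points lower from compound 2 to compound 3 (within the scatter), and not beyond the scatter in either direction. Compound 3 is therefore estimated at 58%, with a range from 40% to 75%.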

Compound 3, a percentage reported as inhibition, at one concentration (the size of the read-out at that concentration, not a potency): 48.1%
Estimate against measurement, compound 3: 9.9 percentage points above; the range from low to high includes it.
By their numbers in this assay, from the lowest: compound 3; then compound 2; then compound 1.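

Exchanging 2-chlorophenyl for 4-methylphenyl on an amine nitrogen in a ring keeps one six-membered aromatic ring of carbon only, yet in this assay it gives a number 12 percentage points lower from compound 2 to compound 3 (beyond the scatter). This single-place step shows that inhibition at this position depends on more than the presence of an aromatic ring: the groups attached to that ring and where they sit can matter. The swap changes both the attached group and where it sits, and no measurement on record explains the drop.

The compounds shown leave open whether chlorine or methyl accounts for the step, or instead where the group sits on the ring. A 4-chlorophenyl or a 2-methylphenyl group at this position would separate those two changes, and an unsubstituted phenyl would show how each group compares with the bare ring.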